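Phenethyl for naphthalen-1-yl on the sulfur

The source may report more compounds than this note shows. Statements on the series, on what has been measured and on what is new or still open speak of the compounds shown alone.

Going by the values given here, in a functional assay on A549 cells (Homo sapiens) for antiproliferative activity, read by CCK-8 assay, with a stated time of 72 h (on this read-out higher numbers stand for weaker inhibition and lower numbers for stronger inhibition), three compounds with a shared core have numbers so far. Compound 1 (`CCc1ccc(SCc2ccc(/C=C/C(=O)Nc3ccccc3N)cc2)cc1`) gives 1300 nM, compound 2 (`Nc1ccccc1NC(=O)/C=C/c1ccc(CSc2ccc(F)cc2)cc1`) gives 1190 nM, and compound 3 (`Nc1ccccc1NC(=O)/C=C/c1ccc(CSc2cccc3ccccc23)cc1`) gives 830 nM. Compound 3 thus stands within the scatter of both others. The next compound, compound 4 (`Nc1ccccc1NC(=O)/C=C/c1ccc(CSCCc2ccccc2)cc1`), carries phenethyl in place of naphthalen-1-yl on a sulfur.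

Two measured steps change the group on that sulfur. They are a 1.6-fold lower number from compound 1 to compound 3 (0.19 log units; within the scatter) and a 1.4-fold lower number from compound 2 to compound 3 (0.16 log units; within the scatter), and both are small and within the scatter. The third step, a 1.1-fold lower number from compound 1 to compound 2 (0.04 log units; within the scatter), is no larger. Among the compounds with values here, none of the measured compounds carries phenethyl, so the data offer only indirect guidance and the range must stay wide. Given the small size of these steps, no change beyond the scatter is expected in this assay. The expected size is a 1.4-fold higher number from compound 3 to compound 4 (0.16 log units; within the scatter). Compound 4 is estimated at 1200 nM, with an expected range of 500 nM to 2900 nM.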

Compound 4, half-maximal inhibitory concentration: 1150 nM
Compound 4: the middle estimate sits 1.0-fold (0.02 log units) above what was measured, within the range that was stated.
By their numbers in this assay, from the lowest: compounds 3, 4, 2 and 1 (each within the scatter of the next).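

In this assay, going by these compounds alone, phenethyl is the first group on this sulfur to carry its aromatic ring on a chain, yet the number stays within the scatter of all three compounds with a ring bound directly to the sulfur: a 1.4-fold higher number from compound 3 to compound 4 (0.14 log units; within the scatter), a 1.0-fold lower number from compound 2 to compound 4 (0.01 log units; within the scatter), and a 1.1-fold lower number from compound 1 to compound 4 (0.05 log units; within the scatter). Among these four compounds, then, neither replacing the two aromatic rings of naphthalen-1-yl with the one ring of phenethyl nor replacing a 4-substituted phenyl with phenethyl moves the number beyond the scatter. No measurement shown here accounts for this flat result.

All four groups on the sulfur contain an aromatic ring of carbon only, so a simple alkyl chain, an amine, or a carboxylic acid at this place remains untested in the compounds shown. From the compounds shown here alone, whether any such group would produce a step beyond the scatter stays open.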